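Swapping a sulfur link for a benzylamine link

A few compounds are considered here, and "the series" means these few. Any claim that something is new, unique, unknown or untested is made for them only; others in the source may bear on it.

Compound 2 `Nc1cc(N)c2nc(-c3ccccc3)c(Sc3ccc(F)cc3)nc2c1` was tested in a functional assay on OVCAR-3 cells (Homo sapiens) for inhibition, read by sulforhodamine B assay, with a stated time of 48 h (on this read-out higher numbers stand for weaker inhibition of growth and lower numbers for stronger inhibition of growth), where compound 2 gives 16200 nM. Among the three compounds measured so far, that number is the second highest: compound 1 `CCOC(=O)[C@H](CCC(=O)O)NC(=O)c1ccc(Sc2nc3cc(N)cc(N)c3nc2-c2ccccc2)cc1` gives 12300 nM, a difference that lies within the usual scatter, while compound 3 `CCOC(=O)[C@H](CCC(=O)O)NC(=O)c1ccc(CNc2nc3cc(N)cc(N)c3nc2-c2ccccc2)cc1` gives 49000 nM, a gap that goes beyond it.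

The next compound, compound 4 `Nc1cc(N)c2nc(-c3ccccc3)c(NCc3ccc(F)cc3)nc2c1`, has not yet been measured. It differs from compound 2 in a single spot: (4-fluorobenzyl)amino in place of (4-fluorophenyl)sulfanyl on an aromatic carbon. The same kind of replacement separates compound 1 from compound 3, and there the values move from the lower number of compound 1 to the higher number of compound 3.

For compound 4 a step upward is therefore expected in this assay, going beyond the scatter, with the estimated change given by a 2.8-fold higher number from compound 2 to compound 4 (0.44 log units; beyond the scatter). On that basis compound 4 is expected to give about 45000 nM, with a likely range from 15000 nM to 140000 nM.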

Compound 4, concentration for 50% growth inhibition: 2400 nM
Compound 4: the middle estimate sits 19-fold (1.27 log units) above what was measured; measured number below the stated range.
By their numbers in this assay, from the lowest: compound 4; then compounds 1 and 2 (each within the scatter of the next); then compound 3.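

In this assay, putting (4-fluorobenzyl)amino in place of (4-fluorophenyl)sulfanyl on this aromatic carbon gives a 6.8-fold lower number from compound 2 to compound 4 (0.83 log units; beyond the scatter) and so stronger inhibition of growth. This shows that the change does not always go the same way at this position: among the compounds carrying the ethyl ester side chain, compound 1 gives 12300 nM and compound 3 gives 49000 nM, a higher number and not a lower one. Nothing measured here accounts for this reversal.

Still open, as far as these compounds go, is whether the gain in compound 4 belongs to the nitrogen link or to the added carbon, which a phenylamino group or a benzyloxy group on this carbon could help separate. A plain benzylamino group would show whether the fluorine matters.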